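The source may hold more compounds than are shown below. What is called first, only, known or untested is meant among the compounds shown, and "the series" means these compounds.

Measured compounds:
- compound 1, `CN(Cc1ccccc1)C(=O)C1CCN(C(=O)c2ccc(S(C)(=O)=O)c([N+](=O)[O-])c2)CC1`; in an assay on isolated protein for inhibition of thyroid hormone receptor beta (Homo sapiens), read by fluorescence polarization (a lower number here means a stronger inhibitor, a higher number a weaker inhibitor), compound 1 gives > 60000 nM, which is a limit of the assay and not a number.
- compound 2, `CCCN(C(=O)CN(C)C(=O)c1ccc(S(C)(=O)=O)c([N+](=O)[O-])c1)c1ccccc1`; in this assay compound 2 gives > 60000 nM, again a limit.
- compound 3, `CN(Cc1ccccc1F)C(=O)C1CCN(C(=O)c2ccc(S(C)(=O)=O)c([N+](=O)[O-])c2)CC1`; in this assay compound 3 gives > 60000 nM, again a limit.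

Compound 2 therefore stands only at a limit in this assay, and the two further values shown are limits too, as stated by the limit of > 60000 nM in this assay, at which 3 of the 3 values shown sit. Within the data shown here, the single step between measured compounds, a step that the two limits leave unreadable from compound 1 to compound 3, cannot be read because the limit of > 60000 nM in this assay, at which 3 of the 3 values shown sit, covers both of its ends.

Compound 4, `CC1CCN(C(=O)CN(C)C(=O)c2ccc(S(C)(=O)=O)c([N+](=O)[O-])c2)CC1`, differs from compound 2 by 4-methylpiperidin-1-yl in place of phenyl(propyl)amino on a carbonyl carbon. Among the measured compounds shown here, no measured step bears on this change. For the measured compounds named here, the series so far offers no value below the limit from which a direction could be taken. Compound 4 is expected to remain at the limit as well. The step from compound 2 to compound 4 is estimated as a step that the limit leaves unreadable from compound 2 to compound 4. In this assay compound 4 is expected at 100000 nM, with a range from 30000 nM to 300000 nM.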

Compound 4, half-maximal inhibitory concentration: > 60000 nM
Compound 4 ended at the assay's limit (the forecaster's own chance of this, stated with the estimate: 85%); the middle value lies beyond the limit too.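

The step from compound 2 to compound 4 cannot be read in this assay, since both ends rest on a limit of the assay and not on a number: the limit of > 60000 nM in this assay, at which 4 of the 4 values shown sit.

The compounds shown leave open which change to the shared core, if any, would bring a value inside that limit.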